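The source may hold more compounds than are shown below. What is called first, only, known or untested is meant among the compounds shown, and "the series" means these compounds.

Compound 2 `COc1cccc(CNCCCNc2ccnc3cc(-c4ccccc4)ccc23)c1O` stands level with its two companions in an ADME assay for permeability, using PAMPA, with a stated time of 30 min, at pH 7.4; a lower number here means that the compound crosses the layer more slowly, a higher number that the compound crosses the layer faster: compound 2 gives 237 10^-6 cm/s, compound 1 `c1ccc(-c2ccc3c(NCCCNCc4ccco4)ccnc3c2)cc1` gives 237 10^-6 cm/s, and compound 3 `COc1ccc(F)cc1CNCCCNc1ccnc2cc(-c3ccccc3)ccc12` gives 237 10^-6 cm/s. The three differ only in the aryl group on the saturated chain carbon bound to the amine nitrogen, and none of those exchanges moved the number: no change at the digits printed from compound 1 to compound 2 (within the scatter), no change at the digits printed from compound 1 to compound 3 (within the scatter) and no change at the digits printed from compound 2 to compound 3 (within the scatter). Compound 4 `COc1cccc(CNCCCNc2ccnc3cc(CC4CCCCC4)ccc23)c1O` keeps the chain and the amine-side group of compound 2 and alters the core instead: cyclohexylmethyl in place of phenyl on an aromatic carbon. For the measured compounds named here, no measured step touches that aromatic carbon, so the three steps bear on it only indirectly, by showing that the read-out has so far been indifferent to every structural exchange tried within this set. With nothing in the measured compounds pointing to a shift in either direction, the step expected in this assay is a 1.0-fold lower number from compound 2 to compound 4 (0.01 log units; within the scatter), that is, none beyond the scatter. Going by the values given here, compound 4 is therefore estimated at 230 10^-6 cm/s in this assay, with a range from 130 10^-6 cm/s to 300 10^-6 cm/s, the width reflecting that the change sits at a place no earlier step has probed.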

Compound 4, apparent permeability: 23 10^-6 cm/s
Compound 4: middle estimate off by 10-fold (1.00 log units), on the high side; the measured number lies below the stated range.
By their numbers in this assay, from the lowest: compound 4; then compounds 1, 2 and 3 (each within the scatter of the next).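

In this assay the aromatic carbon of the shared core that carries phenyl in compound 2 proves to be a place where the read-out responds: cyclohexylmethyl in place of phenyl gives a 10-fold lower number from compound 2 to compound 4 (1.01 log units; beyond the scatter) on this single exchange. For the compounds shown here, the earlier steps all lay in the aryl group on the saturated chain carbon bound to the amine nitrogen and stayed within the scatter, so this is the first change in the set to move the number beyond it. The exchange puts a six-membered non-aromatic ring of carbon only where a six-membered aromatic ring of carbon only stood, with 7 heavy atoms entering for 6, while neither group carries a hydrogen-bond donor, a hydrogen-bond acceptor or a net charge.

The compounds shown leave open whether the step follows the loss of the aromatic ring or the added methylene link, a question that a benzyl group or a cyclohexyl group bound directly at this carbon would address. No measurement shown here gives a reason for the step.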